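Chloro for amino at the limit of the assay

A few compounds are considered here, and "the series" means these few. Any claim that something is new, unique, unknown or untested is made for them only; others in the source may bear on it.

Compound 1 `OC[C@H]1O[C@@H](n2cnc3c(O)ncnc32)CS1` reads > 100000 nM in a functional assay on Vero cells (Chlorocebus sabaeus) for inhibition (on this read-out lower numbers stand for stronger inhibition and higher numbers for weaker inhibition), and this value is a limit, not a number. Compound 2 `Nc1ncnc2c1ncn2[C@H]1CS[C@@H](CO)O1` reads > 100000 nM in this assay and this too is a limit, so compound 2 stands without a number of its own. The record so far is the limit of > 100000 nM in this assay, at which 2 of the 2 values shown sit, and nothing more. Among the measured compounds shown here, compound 3 `OC[C@H]1O[C@@H](n2cnc3c(Cl)ncnc32)CS1` carries chloro in place of amino on an aromatic carbon as its single change from compound 2. For the measured compounds named here, with a step that the two limits leave unreadable from compound 1 to compound 2 as the only measured step, no size can be carried over, so no step beyond the scatter is expected in this assay and no direction is favoured. The estimated step is a number no higher from compound 2 to compound 3 (the limit leaves the size open) and no more. Compound 3 is expected at an estimated 100000 nM within a range of 30000 nM to 300000 nM and may well reach the limit again.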

Compound 3, half-maximal inhibitory concentration: 46500 nM
Compound 3: middle estimate off by 2.2-fold (0.33 log units), on the high side; measured number inside the range.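

On this aromatic carbon the choice of group can move the read-out in this assay: chloro in place of amino gives an at least 2.1-fold lower number from compound 2 to compound 3 (0.33 log units; beyond the scatter), and chloro in place of hydroxy gives an at least 2.1-fold lower number from compound 1 to compound 3 (0.33 log units; beyond the scatter). Both steps start from a limit, so each gives only the smallest size the change can have. Of the three groups shown on this carbon, only chloro gives a number rather than a limit, while amino and hydroxy leave their compounds at the edge of the assay: the limit of > 100000 nM in this assay, at which 2 of the 3 values shown sit.

The step between compound 1 and compound 2 cannot be read, so amino and hydroxy stay unranked against each other. Also open, from the compounds shown here alone, is whether fluoro, bromo or a methoxy group on the same carbon would give a lower number than chloro does in compound 3.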